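Ring-Opened Amine Variant of a Tryptamine Series

This account rests on a few compounds, and the source may have more. Where it says the series, first, only, none or still open, it means among the compounds named here.

Compound 1 `Cc1ccccc1CNCC1(O)CCN(CCCc2c[nH]c3ccc(-n4cnnc4)cc23)CC1` and compound 2 `CC1(C)CCCN(CC2(O)CCN(CCCc3c[nH]c4ccc(-n5cnnc5)cc34)CC2)C1` share a common core and differ only in the amine on a saturated chain carbon bound to a saturated ring carbon. In an assay on CHO cells with 5-hydroxytryptamine receptor 1D (Homo sapiens) as the target (a higher number here means a weaker inhibitor, a lower number a stronger inhibitor), compound 1 gives 4 nM, while compound 2 gives 0.65 nM, so compound 2 stands at the stronger end of the two numbers available, and the step of a 6.2-fold lower number from compound 1 to compound 2 (0.79 log units; beyond the scatter) describes the gain that came with this single replacement.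

Compound 3 `CN(CC1CCCCC1)CC1(O)CCN(CCCc2c[nH]c3ccc(-n4cnnc4)cc23)CC1` has not yet been measured. Its change from compound 2 is (cyclohexylmethyl)(methyl)amino in place of 3,3-dimethylpiperidin-1-yl on a saturated chain carbon bound to a saturated ring carbon. Among the measured compounds shown here, the only measured step, a 6.2-fold lower number from compound 1 to compound 2 (0.79 log units; beyond the scatter), concerns a different pair of groups, so it bears on the new step only loosely: it shows that the amine at this position can move the number by a modest amount, without telling which way an acyclic tertiary amine will go.

Compound 3 is therefore expected to stay close to compound 2, with a step of a 1.5-fold higher number from compound 2 to compound 3 (0.19 log units; within the scatter) that may well lie within the scatter. The estimate for compound 3 in this assay is 1 nM, with a range from 0.3 nM to 4 nM.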

Compound 3, half-maximal inhibitory concentration: 1.2 nM
Compound 3: middle estimate off by 1.2-fold (0.08 log units), on the low side, within the range that was stated.
By their numbers in this assay, from the lowest: compounds 2 and 3 (each within the scatter of the next); then compound 1.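

In this assay, the step of a 1.8-fold higher number from compound 2 to compound 3 (0.27 log units; within the scatter) shows that this place tolerates opening the amine: the nitrogen no longer has to sit inside a ring, as it does in 3,3-dimethylpiperidin-1-yl, for the number to stay within the scatter once the six-membered ring moves out to the cyclohexylmethyl group. The step of a 3.3-fold lower number from compound 1 to compound 3 (0.52 log units; beyond the scatter) then gives a second comparison with the (2-methylbenzyl)amino group of compound 1, so both tertiary amines shown give lower numbers than this one secondary amine, a pattern that rests on these three compounds alone and that none of them goes against. Nothing at hand explains why the numbers fall this way.

The compounds shown leave open whether the gap to compound 1 belongs to the hydrogen on its amine nitrogen or to its aromatic ring, a question that a (2-methylbenzyl)(methyl)amino group at the same place would address. They also leave open how far this place accepts smaller or ring-heteroatom amines, such as dimethylamino or morpholin-4-yl.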